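The source may hold more compounds than are shown below. What is called first, only, known or untested is meant among the compounds shown, and "the series" means these compounds.

Going by the values given here, compound 2 `CCC(CC)CN1CCC(C(=O)Nc2cc(Cl)c(N)cc2OC)CC1` is one of the two measured members. In a functional assay on the whole organism for antagonist activity, with Mus musculus as the target (on this read-out higher numbers stand for an effect only at larger amounts of compound and lower numbers for an effect already at smaller amounts), compound 2 gives > 10 mg/kg, a limit of the assay rather than a number. Compound 1 `COc1cc(N)c(Cl)cc1NC(=O)C1CCN(C/C=C/c2ccccc2)CC1` gives in this assay > 10 mg/kg, again a limit. Among the compounds with values here, the one measured step, a step that the two limits leave unreadable from compound 1 to compound 2, is therefore unreadable, since both of its ends sit at the limit of > 10 mg/kg in this assay, at which 2 of the 2 values shown sit.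

Compound 3 `COc1cc(N)c(Cl)cc1NC(=O)C1CCN(Cc2ccccc2F)CC1` is the next member to be measured in this assay. Its change from compound 2 is 2-fluorophenyl in place of pentan-3-yl on a saturated chain carbon bound to an amine nitrogen in a ring. Within the data shown here, no measured step speaks to this change: the step from compound 1 to compound 2 swaps a 2-phenylethenyl group for a pentan-3-yl group at the saturated chain carbon bound to an amine nitrogen in a ring, and its size cannot be read, so no direction is known for a 2-fluorophenyl group entering there. For compound 3 the step that the limit leaves unreadable from compound 2 to compound 3 is expected to stay within the scatter or, more likely, to remain unreadable. Compound 3 is estimated at 12 mg/kg in this assay, in the range 3 mg/kg to 40 mg/kg, with a limit more probable than a number.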

Compound 3, dose for half-maximal effect: > 4 mg/kg
Compound 3 gave a limit, no number; the forecaster's own chance of this, stated with the estimate: 65%; the middle value does not contradict the limit.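

In this assay compound 3 gives > 4 mg/kg, a limit and not a number. The steps from compound 1 and compound 2 to compound 3 cannot be read, as all three values are limits. The compounds shown leave open whether any group on the saturated chain carbon bound to an amine nitrogen in a ring shifts the half-maximal dose, and how far.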